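Tetrazole replaces the sulfonic acid on the thiocarbamate chain

This account rests on a few compounds, and the source may have more. Where it says the series, first, only, none or still open, it means among the compounds named here.

Compound 2 `O=S(=O)(O)CCCSC(=S)NCc1cccnc1` gives the highest of the two numbers in a functional assay on Bel-7402 cells (Homo sapiens) for cytotoxicity, read by resazurin assay, with a stated time of 72 h (on this read-out higher numbers stand for weaker inhibition and lower numbers for stronger inhibition), at 6590 nM. Compound 1 `OCCCSC(=S)NCc1cccnc1` gives 3650 nM in this assay, and a 1.8-fold higher number from compound 1 to compound 2 (0.26 log units; within the scatter). Compound 3 `S=C(NCc1cccnc1)SCCc1nnn[nH]1` differs from compound 2 by 1H-tetrazol-5-yl in place of sulfomethyl on a saturated chain carbon, two bonds along the chain from a sulfur. For the measured compounds named here, the only measured step, which also exchanged one chain end for another, stayed within the scatter, so no step beyond the scatter is expected here either. Compound 3 is therefore estimated at 5000 nM, with a range from 1500 nM to 16000 nM. The expected step is a 1.3-fold lower number from compound 2 to compound 3 (0.12 log units; within the scatter).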

Compound 3, half-maximal inhibitory concentration: 57700 nM
Compound 3: the middle estimate sits 12-fold (1.06 log units) below what was measured; measured number above the stated range.
By their numbers in this assay, from the lowest: compounds 1 and 2 (each within the scatter of the next); then compound 3.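

In this assay, this chain end turns out not to be indifferent: 1H-tetrazol-5-yl in place of sulfomethyl gives an 8.8-fold higher number from compound 2 to compound 3 (0.94 log units; beyond the scatter), and in place of hydroxymethyl it gives a 16-fold higher number from compound 1 to compound 3 (1.20 log units; beyond the scatter). The earlier change from hydroxy to sulfo had shown no step beyond the scatter, so compound 3 is the first sign that the group at this place matters. No evidence is available to explain the loss. The compounds shown leave open whether a carboxylic acid at this chain end, or the 1H-tetrazol-5-yl on a longer chain, would return to the level of compound 1 and compound 2.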